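Swapping the aryl on the triazole: nitro to difluoro

The source may hold more compounds than are shown below. What is called first, only, known or untested is meant among the compounds shown, and "the series" means these compounds.

Measured so far:
compound 1 `COc1ccc(-n2nncc2CN2C(=O)C3(C(C#N)=C(N)Oc4c(N)cc5nc6ccccc6nc5c43)c3ccccc32)cc1` — > 50000 nM
compound 2 `N#CC1=C(N)Oc2c(N)cc3nc4ccccc4nc3c2C12C(=O)N(Cc1cnnn1-c1ccc([N+](=O)[O-])cc1)c1ccccc12` — > 50000 nM

In a functional assay on A549 cells (Homo sapiens) for antiproliferative activity, read by MTT assay, with a stated time of 48 h (on this read-out higher numbers stand for weaker inhibition and lower numbers for stronger inhibition), compound 1 gives only a limit of the assay, > 50000 nM. Compound 2 likewise reaches only a limit, > 50000 nM. The step from compound 1 to compound 2, a step that the two limits leave unreadable from compound 1 to compound 2, cannot be sized because of the limit of > 50000 nM in this assay, at which 2 of the 2 values shown sit. Compound 2 therefore stands at the edge of what this assay can report, with no number of its own.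

Compound 3, `N#CC1=C(N)Oc2c(N)cc3nc4ccccc4nc3c2C12C(=O)N(Cc1cnnn1-c1c(F)cccc1F)c1ccccc12`, is not yet measured. It differs from compound 2 in one place: 2,6-difluorophenyl in place of 4-nitrophenyl on an aromatic nitrogen. Among the measured compounds shown here, no measured step touches this change; the single step seen so far is unreadable. Compound 3 is expected to stay at the limit too, with an estimate of 50000 nM and a range from 10000 nM to 100000 nM. The expected step of a number no higher from compound 2 to compound 3 (the limit leaves the size open) is thus no readable change.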

Compound 3, half-maximal inhibitory concentration: > 50000 nM
Compound 3: no number, only a limit; the forecaster's own chance of this, stated with the estimate: 75%; the middle value lies on the limit itself.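

The steps among compound 1, compound 2 and compound 3 cannot be read, because none of the three has a number of its own: the limit of > 50000 nM in this assay, at which 3 of the 3 values shown sit.

The compounds shown leave open whether 4-methoxyphenyl, 4-nitrophenyl and 2,6-difluorophenyl differ at all in their effect on these cells.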